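This account rests on a few compounds, and the source may have more. Where it says the series, first, only, none or still open, it means among the compounds named here.

Measured so far:
compound 1 `COc1cccc(C#Cc2ccc3c(n2)CCN(C)C3=O)c1`, 3660 nM
compound 2 `O=C1c2ccc(C#Cc3cccc(Cl)c3)nc2CCN1C1CCCC1`, 5230 nM

In an assay on HEK293 cells for displacement of a labelled ligand from metabotropic glutamate receptor 5 (Homo sapiens), with a stated time of 2 h (on this read-out lower numbers stand for stronger inhibition and higher numbers for weaker inhibition), compound 2 gives 5230 nM, the higher of the two numbers so far, while compound 1 gives 3660 nM; the two values lie within the usual scatter of each other, so no real difference between them is shown. Compound 3 `COc1cccc(C#Cc2ccc3c(n2)CCN(C2CCCC2)C3=O)c1` has not yet been measured in this assay. It differs from compound 2 in one place: methoxy in place of chloro on an aromatic carbon. Compound 1 already carries a methoxy group on that ring, but it also differs from compound 2 and compound 3 elsewhere, so its value alone cannot say what the exchange of chloro for methoxy does. For the measured compounds named here, with no directly comparable pair among the measured compounds, the expected step from compound 2 to compound 3 is a 1.2-fold lower number from compound 2 to compound 3 (0.07 log units; within the scatter), that is, none beyond the scatter. Compound 3 is therefore estimated at 4500 nM, in a range from 1500 nM to 13000 nM.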

Compound 3, inhibition constant: > 32000 nM
Compound 3 ended at the assay's limit (the forecaster's own chance of this, stated with the estimate: 10%); middle value at least 7.1-fold (0.85 log units) from the limit.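

In this assay, the group on this aromatic carbon matters when the amide-type nitrogen carries cyclopentyl: methoxy in place of chloro gives an at least 6.1-fold higher number from compound 2 to compound 3 (0.78 log units; beyond the scatter) and so loses the measurable binding. The group on the nitrogen matters as well, since cyclopentyl in place of methyl gives an at least 8.7-fold higher number from compound 1 to compound 3 (0.94 log units; beyond the scatter) with the 3-methoxyphenyl group unchanged. The result for compound 3 is a limit of the assay and not a number, so each step gives only a minimum size: the limit of > 32000 nM in this assay, at which 1 of the 3 values shown sits.

The compounds shown cannot tell whether 3-chlorophenyl would respond in the same way to cyclopentyl in place of methyl, so it stays unclear whether the two changes depend on each other. They also leave open how fluoro, hydroxy or an amine on this aromatic carbon would compare with chloro and methoxy.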